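The compounds below may be only part of what the source reports. "The series", "measured", "known", "first", "only" and "open" are said of these compounds alone.

Among the compounds with values here, in a functional assay on Jurkat cells (Homo sapiens) for activation, with a stated time of 24 h (a lower number here means that less compound is needed, a higher number that more compound is needed for the effect), compound 3 `Oc1ccccc1CNc1ccc(-c2ccc(Cl)cc2)cc1` gives 2390 nM, the higher of the two numbers so far, though compound 2 `Oc1ccccc1CNc1ccc(-c2ccccc2)cc1` gives 1820 nM and the step of a 1.3-fold higher number from compound 2 to compound 3 (0.12 log units; within the scatter) lies within the scatter. Compound 1 `Oc1cc(F)ccc1CNc1ccc(C2CCCCC2)cc1` is reported as "not active" (no number reported). Compound 4 `Oc1ccccc1CNc1ccc(C2CCCCC2)cc1` has not been measured. It differs from compound 3 by cyclohexyl in place of 4-chlorophenyl on an aromatic carbon. Within the data shown here, no measured step covers an aromatic ring giving way to a non-aromatic one, so the single step measured here does not bear on it; the only hint comes from compound 1, which also carries cyclohexyl and gave "not active" (no number reported). On that basis compound 4 is expected to need more compound, with an estimated step of a 2.5-fold higher number from compound 3 to compound 4 (0.40 log units; beyond the scatter), and a fair chance of no number at all. The estimate for compound 4 in this assay is 6000 nM, within a range from 1500 nM to 30000 nM.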

Compound 4, half-maximal effective concentration: 8800 nM
Estimate against measurement, compound 4: 1.5-fold (0.17 log units) below, and the stated range covers the measured number.
By their numbers in this assay, from the lowest: compounds 2 and 3 (each within the scatter of the next); then compound 4.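

In this assay, replacing the aromatic ring at this position with cyclohexyl is the first change shown to move the number beyond the scatter: a 3.7-fold higher number from compound 3 to compound 4 (0.57 log units; beyond the scatter) and a 4.8-fold higher number from compound 2 to compound 4 (0.68 log units; beyond the scatter) both point the same way. Cyclohexyl alone still leaves a measurable effect, while compound 1, which also has a fluoro group, gives "not active" (no number reported) and so offers no number for comparison. Nothing shown explains the loss. Going by these compounds, whether this position needs a ring at all remains open. A straight hexyl chain or a carboxylic acid there could answer that.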